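This account rests on a few compounds, and the source may have more. Where it says the series, first, only, none or still open, it means among the compounds named here.

Compound 1 `O=C(Nc1ccc(-n2ncc3c(C(F)(F)F)cccc32)cc1)Nc1ccc(Cl)c(C(F)(F)F)c1` is a urea joining two aromatic groups, with a trifluoromethyl on an aromatic carbon of the shared core. For the measured compounds named here, in a functional assay on MDA-MB-231 cells (Homo sapiens) for cytotoxicity, read by MTT assay, with a stated time of 72 h (on this read-out higher numbers stand for weaker inhibition and lower numbers for stronger inhibition), compound 1 gives 2000 nM, the lowest of the three numbers measured so far. Compound 2 `Cc1cccc2c1cnn2-c1ccc(NC(=O)Nc2ccc(Cl)c(C(F)(F)F)c2)cc1`, carrying methyl in place of that trifluoromethyl, gives 2300 nM in this assay, a change of a 1.2-fold higher number from compound 1 to compound 2 (0.06 log units; within the scatter). Compound 3 `O=C(Nc1ccc(-n2ncc3ccccc32)cc1)Nc1ccc(Cl)c(C(F)(F)F)c1`, with hydrogen on that aromatic carbon, gives 5000 nM; the steps are a 2.5-fold higher number from compound 1 to compound 3 (0.40 log units; beyond the scatter) and a 2.2-fold higher number from compound 2 to compound 3 (0.34 log units; beyond the scatter).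

Compound 4 `O=C(Nc1ccc(-n2ncc3c(C(F)(F)F)cccc32)cc1)Nc1ccc(C(F)(F)F)cc1` changes a different part of the molecule: 4-(trifluoromethyl)phenyl in place of 4-chloro-3-(trifluoromethyl)phenyl on an amide-type nitrogen. Going by the values given here, all three measured steps concern the substituent on the shared core, and none touches the group on the amide-type nitrogen, so no measured step bears directly on this change. Without a guide, a modest weakening in this assay is expected, a 2.0-fold higher number from compound 1 to compound 4 (0.30 log units; within the scatter), with wide uncertainty. For compound 4 the estimate in this assay is 4000 nM, in a range from 1500 nM to 12000 nM.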

Compound 4, half-maximal inhibitory concentration: 2000 nM
For compound 4 the middle estimate is 2.0-fold (0.30 log units) above the measured one, and the stated range covers the measured number.
By their numbers in this assay, from the lowest: compounds 1, 4 and 2 (each within the scatter of the next); then compound 3.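

For the compounds shown here, compound 4 is the first compound here to vary the group on the amide-type nitrogen rather than the substituent on the shared core, and in this assay the result is no change at the digits printed from compound 1 to compound 4 (within the scatter) for this swap. On this core, then, 4-(trifluoromethyl)phenyl and 4-chloro-3-(trifluoromethyl)phenyl cannot be told apart in this read-out, so the chlorine is not needed to keep the number where it stands. Nothing available explains why the two groups read alike.

The compounds shown leave open whether the same swap would read the same way on the methyl core of compound 2 or the unsubstituted core of compound 3. Also open, from the compounds shown here alone, is how a phenyl carrying an amine or a carboxylic acid in place of trifluoromethyl, or a longer alkyl chain on that nitrogen, would behave in this assay.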